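The source may report more compounds than this note shows. Statements on the series, on what has been measured and on what is new or still open speak of the compounds shown alone.

The shared core carries a varied group on one aromatic carbon, and three compounds have been measured. In a physicochemical assay for acid dissociation, compound 3 `COc1cccc(CNCCCNc2ccnc3cc(Oc4ccc(C(C)(C)C)cc4)ccc23)c1O` gives 9.28. Compound 1 `COc1cccc(CNCCCNc2ccnc3cc(Oc4ccc(F)cc4)ccc23)c1O` gives 9.28, and compound 2 `COc1cccc(CNCCCNc2ccnc3cc(-c4cccc5ccccc45)ccc23)c1O` gives 9.47. The three numbers all lie within the scatter of one another: the step of no change at the digits printed from compound 1 to compound 3 (within the scatter) and the step of a number 0.19 log units lower from compound 2 to compound 3 (within the scatter) both stay inside it, as does the step of a number 0.19 log units higher from compound 1 to compound 2 (within the scatter).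

Compound 4 `COc1cccc(CNCCCNc2ccnc3cc(Cc4cccc(C(F)(F)F)c4)ccc23)c1O` differs from compound 3 in one place: 3-(trifluoromethyl)benzyl in place of 4-(tert-butyl)phenoxy on an aromatic carbon. The three measured steps bear on this change, since each also swaps what sits on that same aromatic carbon, and none of them moved the number beyond the scatter. The expectation for the step of a number 0.02 log units higher from compound 3 to compound 4 (within the scatter) is therefore that nothing beyond the scatter appears. For compound 4 the estimated value in this assay is 9.3, expected to fall between 9 and 9.6.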

Compound 4, acid dissociation constant: 9.47
For compound 4 the middle estimate is 0.17 log units below the measured one; the range from low to high includes it.
By their numbers in this assay, from the lowest: compounds 1, 3, 2 and 4 (each within the scatter of the next).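

Read in this assay, the swap of 4-(tert-butyl)phenoxy, which counts a hydrogen-bond acceptor, for 3-(trifluoromethyl)benzyl, which counts none, gives a number 0.19 log units higher from compound 3 to compound 4 (within the scatter) and so stays inside the usual scatter. Against the other two groups the steps read no change at the digits printed from compound 2 to compound 4 (within the scatter) and a number 0.19 log units higher from compound 1 to compound 4 (within the scatter) as well, so four different groups on this aromatic carbon now lie within the scatter of one another in this assay with no step beyond it. No measurement at hand explains why this number holds so steady.

Each of the four groups carries aromatic rings of carbon only, so the compounds shown leave open whether an amine, a carboxylic acid or a short alkyl chain on this aromatic carbon would also stay inside the scatter. They also leave open whether a change elsewhere on the shared core would move the number.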